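From 3-Fluorophenyl to 2-Hydroxyphenyl on the Sulfonyl Sulfur

The compounds below may be only part of what the source reports. "The series", "measured", "known", "first", "only" and "open" are said of these compounds alone.

Compound 1 `O=S(=O)(Nc1ccc(-c2nc3ccccc3o2)cc1)c1cccc(F)c1` is a sulfonamide on a shared core, carrying a 3-fluorophenyl group on its sulfonyl sulfur. In an ADME assay on HEK293 cells (Homo sapiens) for cytotoxicity, read by resazurin assay, with a stated time of 48 h (on this read-out higher numbers stand for lower toxicity in this test and lower numbers for higher toxicity in this test), compound 1 gives > 100000 nM, which is a limit of the assay and not a measured number. Two related compounds give numbers instead: compound 2 `COc1ccccc1S(=O)(=O)Nc1ccc2oc(-c3ccccc3)nc2c1` gives 41000 nM in this assay, and compound 3 `O=[N+]([O-])c1cc(S(=O)(=O)Nc2ccc(-c3nc4ccccc4o3)cc2)ccc1Cl` gives 85000 nM. Compound 1 thus stands at the limit, where one of the three values sits (the limit of > 100000 nM in this assay, at which 1 of the 3 values shown sits), with the other two not far from it.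

Compound 4 `O=S(=O)(Nc1ccc(-c2nc3ccccc3o2)cc1)c1ccccc1O` differs from compound 1 in a single place: 2-hydroxyphenyl in place of 3-fluorophenyl on a sulfonyl sulfur. Within the data shown here, no measured step between two compounds that differ in only one place is available, so the expectation rests on how narrowly the three known values are grouped. The step from compound 1 to compound 4 is expected to be an at least 1.2-fold lower number from compound 1 to compound 4 (0.09 log units; that floor lies within the scatter), within the usual scatter and in no clear direction. Compound 4 is therefore estimated at 80000 nM, with a range from 30000 nM to 200000 nM.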

Compound 4, half-maximal cytotoxic concentration: > 100000 nM
Compound 4 was reported as a limit; the forecaster's own chance of this, stated with the estimate: 50%; middle value at least 1.2-fold (0.09 log units) from the limit.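

Among these compounds, the results for compound 1 and compound 4 in this assay are both limits and not measured numbers, and no step between the two can be read. The compounds shown leave open how 2-hydroxyphenyl and 3-fluorophenyl on a sulfonyl sulfur compare on this read-out.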